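From an acetamide chain to a phenylethyl group

The compounds below may be only part of what the source reports. "The series", "measured", "known", "first", "only" and "open" are said of these compounds alone.

Compound 1, `COc1cc(Oc2cccc(Nc3ccccc3)c2)cc(OC)c1CNCc1ccc(F)cc1`, gives 3640 nM in a functional assay on HCT-15 cells (Homo sapiens) for inhibition, read by MTT assay, with a stated time of 72 h; a lower number here means a stronger inhibitor, a higher number a weaker inhibitor.
Compound 2, `CNCc1c(OC)cc(Oc2cccc(Nc3ccccc3)c2)cc1OC`, gives 8930 nM in this assay.
Compound 3, `COc1cc(Oc2cccc(Nc3ccccc3)c2)cc(OC)c1CNCCNC(C)=O`, gives 5090 nM in this assay.

All three share one core and differ only in the group carried on the amine nitrogen. Compound 3 cannot be set apart from either neighbour: one gap is a 1.4-fold higher number from compound 1 to compound 3 (0.15 log units; within the scatter), and the other gap is a 1.8-fold lower number from compound 2 to compound 3 (0.24 log units; within the scatter). Going by the values given here, only the step of a 2.5-fold higher number from compound 1 to compound 2 (0.39 log units; beyond the scatter), which swaps the 4-fluorophenyl for hydrogen, is beyond the scatter.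

Compound 4, `COc1cc(Oc2cccc(Nc3ccccc3)c2)cc(OC)c1CN[C@H](C)c1ccccc1`, is reached from compound 3 by 1-phenylethyl in place of 2-acetamidoethyl on an amine nitrogen. The step that bears most on it is the comparison of compound 1 with compound 3, which was a 1.4-fold higher number from compound 1 to compound 3 (0.15 log units; within the scatter): exchanging an aromatic ring for an acetamide-bearing chain changed little, and the reverse exchange is expected to change little as well. Compound 1 shows the lowest of the three numbers, so a step downward is expected for compound 4, estimated as a 1.7-fold lower number from compound 3 to compound 4 (0.23 log units; within the scatter). In this assay compound 4 is therefore estimated at 3000 nM, within a range from 1200 nM to 7500 nM.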

Compound 4, half-maximal inhibitory concentration: 7550 nM
The estimate for compound 4 lay 2.5-fold (0.40 log units) below the measured number; measured number outside the range, above it.
By their numbers in this assay, from the lowest: compounds 1, 3, 4 and 2 (each within the scatter of the next, the first and the last beyond it).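

The 1-phenylethyl group of compound 4 brings an aromatic ring onto the amine nitrogen, yet in this assay it cannot be told apart from 2-acetamidoethyl (a 1.5-fold higher number from compound 3 to compound 4 (0.17 log units; within the scatter)) or from methyl (a 1.2-fold lower number from compound 2 to compound 4 (0.07 log units; within the scatter)). Compound 1 also carries an aromatic ring at this place, and its 4-fluorobenzyl group does separate from 1-phenylethyl, though only modestly (a 2.1-fold higher number from compound 1 to compound 4 (0.32 log units; beyond the scatter)), so an aromatic ring on this nitrogen is not enough on its own to bring a compound level with compound 1. No measured evidence is available here to account for this difference.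

The change from 4-fluorobenzyl to 1-phenylethyl alters several things at once: the fluorine leaves, a methyl branch enters and a defined stereocentre enters, and the compounds shown do not say which of these matters. Plain benzyl and the mirror-image form of 1-phenylethyl on the same nitrogen would help to pull these apart, and whether any group here can reach a number clearly below that of compound 1 remains open.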